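Changing the amide side group of compound 3

A few compounds are considered here, and "the series" means these few. Any claim that something is new, unique, unknown or untested is made for them only; others in the source may bear on it.

In an ADME assay on microsomes from liver (Mus musculus, strain CD-1) for metabolic stability, read by LC-MS, tested at 2 uM (a lower number here means that the compound disappears faster, a higher number that the compound lasts longer), compound 3 `CC(=O)N1CCCC(NC(=O)c2ccncc2Nc2cc(-c3ccc4ccn(C)c4c3)c3nccnc3c2)C1` gives 0.4 h, which lies within the usual scatter of both compound 1 `CN(C)S(=O)(=O)c1ccccc1Nc1cc(-c2ccc3ccn(C)c3c2)c2nccnc2c1` (0.233 h) and compound 2 `CN(Cc1cncnc1)S(=O)(=O)c1ccccc1Nc1cc(-c2ccc3ccn(C)c3c2)c2nccnc2c1` (0.2 h). Compound 4 `CN1CCC(N(C)C(=O)c2ccncc2Nc2cc(-c3ccc4ccn(C)c4c3)c3nccnc3c2)C1` has not yet been measured, and it differs from compound 3 on a carbonyl carbon (methyl(1-methylpyrrolidin-3-yl)amino in place of (1-acetylpiperidin-3-yl)amino on a carbonyl carbon). Within the data shown here, the only measured step between close relatives (a 1.2-fold lower number from compound 1 to compound 2 (0.07 log units; within the scatter)) adds pyrimidin-5-yl at a different place, on a saturated chain carbon bound to a sulfonamide nitrogen, so it offers only weak guidance. It does stay within the scatter, and no change beyond the scatter is expected here (a 1.3-fold lower number from compound 3 to compound 4 (0.12 log units; within the scatter)). Compound 4 is estimated at 0.3 h (range 0.12 h to 0.7 h).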

Compound 4, half-life: > 1 h
Compound 4 ended at the assay's limit; the forecaster's own chance of this, stated with the estimate: 3%; middle value at least 3.3-fold (0.52 log units) away from the limit.
By their numbers in this assay, from the lowest: compounds 2, 1 and 3 (each within the scatter of the next). At a limit, above all of these: compound 4.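

The group on this carbonyl carbon matters in this assay: methyl(1-methylpyrrolidin-3-yl)amino in place of (1-acetylpiperidin-3-yl)amino gives the only step shown that lies beyond the scatter (an at least 2.5-fold higher number from compound 3 to compound 4 (0.39 log units; beyond the scatter)). The value of compound 4 is a limit, not a number: the limit of > 1 h in this assay, at which 1 of the 4 values shown sits. The swap changes the ring size, the acetyl group and the amide hydrogen at once, so the compounds shown cannot separate these changes. On these data alone, whether a methyl(1-methylpiperidin-3-yl)amino group on the same carbonyl carbon would last as long remains open.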